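The source may hold more compounds than are shown below. What is called first, only, known or untested is meant among the compounds shown, and "the series" means these compounds.

Measured so far:
compound 1, `COc1ccc(OC)c(/C=C/c2nnc(Nc3ccc(Cl)cc3)o2)c1`: 9870 nM in a functional assay on Malme-3M cells (Homo sapiens) for antiproliferative activity, read by sulforhodamine B assay, with a stated time of 48 h; a higher number here means a weaker inhibitor of growth, a lower number a stronger inhibitor of growth
compound 2, `COc1ccc(OC)c(/C=C/C(=O)N/N=C/c2ccc(Cl)cc2)c1`: "not determined" (no result reported) in this assay

Compound 2 has no single number in this assay; only compound 1, on a different core, supplies a value, and that value is weak. Compound 3, `COc1ccc(OC)c(/C=C/C(=O)N/N=C/c2ccccc2)c1`, is to be measured in this assay. It differs from compound 2 by hydrogen in place of chloro on an aromatic carbon, read one bond further out as 4-chlorophenyl to phenyl. With no measured step of this kind in the series, no direction beyond the scatter is expected, and the value of compound 1 serves as the only anchor. Compound 3 is expected to give about 15000 nM in this assay, with a range of 3000 nM to 70000 nM.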

Compound 3, concentration for 50% growth inhibition: 2120 nM
Compound 3: middle estimate off by 7.1-fold (0.85 log units), on the high side; measured number outside the range, below it.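

Going by these compounds alone, compound 2 has no number in this assay, and no step to compound 3 can be read. The compounds shown leave open what 4-chlorophenyl to phenyl does to growth inhibition. No measured evidence bears on this result.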